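The source may hold more compounds than are shown below. What is called first, only, known or untested is meant among the compounds shown, and "the series" means these compounds.

Of the compounds shown here, two have been read so far in a functional assay on HT-29 cells (Homo sapiens) for antiproliferative activity, read by XTT assay, with a stated time of 72 h; on this read-out higher numbers stand for weaker inhibition and lower numbers for stronger inhibition. Compound 1 `C=C(C)CCC[C@]1(C)C2=CCC[C@](C)(CC(=O)c3ccoc3)[C@H]2CC[C@H]1C` gives > 100000 nM, which is a limit of the assay and not a number. Within the data shown here, compound 2 `C=C(C)CCC[C@]1(C)C2=CCC[C@](C)(C[C@@H](OC(C)=O)C3=CC(=O)OC3O)[C@H]2CC[C@H]1C` gives 2900 nM, the only true number so far, so there is no measured value to rank it against. Compound 3 `C=C(C)CCC[C@]1(C)C2=CCC[C@](C)(C[C@@H](O)C3=CC(=O)OC3O)[C@H]2CC[C@H]1C` has yet to be measured in this assay. It differs from compound 2 by one change, hydrogen in place of acetyl on an oxygen on a saturated carbon. Among the measured compounds shown here, no measured step covers this acetoxy to hydroxy change, so the expectation rests on compound 2 alone, at 2900 nM. The expected step of a 1.0-fold higher number from compound 2 to compound 3 (0.01 log units; within the scatter) stays within the usual scatter, with no direction favoured. For compound 3 the estimated value is 3000 nM, with an expected range from 1000 nM to 10000 nM.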

Compound 3, half-maximal inhibitory concentration: 2300 nM
The estimate for compound 3 lay 1.3-fold (0.12 log units) above the measured number, and the stated range covers the measured number.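

In this assay, acetoxy to hydroxy on the oxygen on a saturated carbon gives a 1.3-fold lower number from compound 2 to compound 3 (0.10 log units; within the scatter) and so the acetyl can leave this place without a shift beyond the scatter. The group of 9 heavy atoms with its five-membered non-aromatic ring, in place of the group of 7 heavy atoms with its five-membered aromatic ring, gives an at least 43-fold lower number from compound 1 to compound 3 (1.63 log units; beyond the scatter) and so the large step in the series belongs to that exchange on the saturated chain carbon, not to the acetyl. The step is open-ended, as compound 1 stands at a limit of the assay and not at a number: the limit of > 100000 nM in this assay, at which 1 of the 3 values shown sits.

Which part of the group of 9 heavy atoms carries that step remains open. Also open, from the compounds shown here alone, is how this place responds to a methyl ether, an amine or an ester longer than acetyl.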